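Chalcone-Pyrazole Series: Swapping the Aminophenyl for Difluorophenyl

The compounds below may be only part of what the source reports. "The series", "measured", "known", "first", "only" and "open" are said of these compounds alone.

Measured compounds:
compound 1 `COc1cc(-c2cc(/C=C/C(=O)c3ccc(N)cc3)[nH]n2)cc(OC)c1OC`: 2480 nM
compound 2 `COc1ccc(-c2cc(/C=C/C(=O)c3ccc(N)cc3)[nH]n2)cc1OC`: 4210 nM
compound 3 `COc1ccc(-c2cc(/C=C/C(=O)c3cc(OC)c(OC)c(OC)c3)[nH]n2)cc1OC`: 1970 nM

In a functional assay on NCI-H23 cells (Homo sapiens) for inhibition, read by sulforhodamine B assay, with a stated time of 48 h (on this read-out higher numbers stand for weaker inhibition of growth and lower numbers for stronger inhibition of growth), compound 1 gives 2480 nM, the second highest of the three numbers. Its nearest neighbour is compound 3 at 1970 nM, a gap within the scatter; the furthest is compound 2 at 4210 nM, where a 1.7-fold higher number from compound 1 to compound 2 (0.23 log units; within the scatter), also within the scatter.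

Compound 4 `COc1cc(-c2cc(/C=C/C(=O)c3ccc(F)c(F)c3)[nH]n2)cc(OC)c1OC` differs from compound 1 by 3,4-difluorophenyl in place of 4-aminophenyl on a carbonyl carbon. Among the measured compounds shown here, no measured step changes the ring on the carbonyl carbon while leaving everything else fixed. For the measured compounds named here, the only measured step, from compound 1 to compound 2, alters the other aromatic ring and stays within the scatter, and compound 3, which also carries a different ring on the carbonyl carbon, sits within the scatter of compound 1. Nothing here therefore points to a shift beyond the scatter. Compound 4 is expected to show a 1.0-fold higher number from compound 1 to compound 4 (0.00 log units; within the scatter), landing in the same region. The estimate for compound 4 is 2500 nM, with a range from 900 nM to 7000 nM.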

Compound 4, concentration for 50% growth inhibition: 2600 nM
Beside the measured number, compound 4's estimate is 1.0-fold (0.02 log units) below it; low and high end bracket the measured number.
By their numbers in this assay, from the lowest: compounds 3, 1, 4 and 2 (each within the scatter of the next, the first and the last beyond it).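

In this assay, a 1.0-fold higher number from compound 1 to compound 4 (0.02 log units; within the scatter) is the first step shown that changes only the ring on the carbonyl carbon, and it stays within the scatter. The hydrogen-bond donor and acceptor counted on 4-aminophenyl are absent from 3,4-difluorophenyl, yet on the core of compound 1 this exchange leaves the read-out within the scatter, so at this place neither the amino group nor the two fluorines sets the number apart. Nothing measured here explains this result.

From the compounds shown here alone, it remains open whether a ring carrying a carboxylic acid or a dimethylamino group at this place would also stay within the scatter of compound 1. The compounds shown also leave open whether 3,4-difluorophenyl would behave the same way on the core of compound 2.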